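The compounds below may be only part of what the source reports. "The series", "measured", "known", "first", "only" and "open" are said of these compounds alone.

In an assay on isolated protein for inhibition of Amine oxidase [flavin-containing] A (Homo sapiens), read by fluorescence, with a stated time of 30 min (on this read-out lower numbers stand for stronger inhibition and higher numbers for weaker inhibition), compound 2 `COc1cc2sn(CCCCN(C)Cc3ccccc3)c(=O)c2cc1OC` gives 8900 nM, the lowest of the three numbers. Compound 1 `COc1ccccc1CN(C)CCCn1sc2cc(OC)c(OC)cc2c1=O` gives 9400 nM, within the scatter of compound 2. Compound 3 `CCN(CCCCn1sc2cc(OC)c(OC)cc2c1=O)Cc1ccccc1` gives 19900 nM, and the step of a 2.2-fold higher number from compound 2 to compound 3 (0.35 log units; beyond the scatter) puts methyl in place of hydrogen on a saturated chain carbon bound to an amine nitrogen. Compound 4 `COc1ccccc1CN(C)CCCCn1sc2cc(OC)c(OC)cc2c1=O` differs from compound 2 by methoxy in place of hydrogen on an aromatic carbon, on an aromatic carbon of a six-membered aromatic ring of carbon only. Within the data shown here, no measured step isolates this change: compound 1 also carries the methoxy group, but it differs from compound 2 elsewhere as well, and its value sits within the scatter of compound 2. The expected step is a 1.0-fold higher number from compound 2 to compound 4 (0.00 log units; within the scatter), nothing beyond the scatter. Compound 4 is expected to give about 9000 nM, between 4500 nM and 18000 nM.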

Compound 4, half-maximal inhibitory concentration: 7100 nM
The estimate for compound 4 lay 1.3-fold (0.10 log units) above the measured number, and the stated range covers the measured number.
By their numbers in this assay, from the lowest: compounds 4, 2 and 1 (each within the scatter of the next); then compound 3.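

Turning the benzyl group into 2-methoxybenzyl isolates the methoxy group for the first time, since compound 1 carries it but differs elsewhere too. The result, a 1.3-fold lower number from compound 2 to compound 4 (0.10 log units; within the scatter), shows no readable gain or loss in this assay, so this aromatic carbon, ortho to a large group, accepts a methoxy group without a change beyond the scatter. Nothing available explains this outcome. Going by these compounds, whether a hydroxyl group, a chlorine atom or a carboxylic acid at this place would shift the number beyond the scatter remains open.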